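This account rests on a few compounds, and the source may have more. Where it says the series, first, only, none or still open, it means among the compounds named here.

Compound 1 `Cc1c(C(=O)Nc2c(F)cc(-c3cccc(F)c3)cc2F)nc2ccc(C(F)(F)F)cc2c1O` is the reference point of this account. In a functional assay on A-375 cells (Homo sapiens) for antiproliferative activity, read by MTT assay, with a stated time of 24 h, tested at 3.7 ug/mL (on this read-out lower numbers stand for a weaker effect and higher numbers for a stronger effect at the one concentration tested), compound 1 gives 34.3%, the highest of the three numbers obtained so far. Compound 2 `COc1ccc2nc(C(=O)Nc3ccc(-c4ccccc4)cc3)c(C)c(O)c2c1` gives 27.2% in this assay, a number that differs from compound 1 only within the usual scatter of repeated measurements. Compound 3 `Cc1c(C(=O)Nc2ccc(-c3ccccc3)cc2)nc2ccccc2c1O` gives 17.3% in this assay, which lies beyond the scatter below compound 1. For the measured compounds named here, the one step between measured compounds that differ in a single place is a number 9.9 percentage points lower from compound 2 to compound 3 (within the scatter), a change that does not touch the part of the shared core altered here.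

Compound 4 `Cc1c(C(=O)Nc2c(F)cc(-c3cccc(F)c3)cc2F)nc2ccc(C(F)(F)F)cc2c1C(=O)O` differs from compound 1 in one place: carboxy in place of hydroxy on an aromatic carbon. Going by the values given here, no measured pair shows this exchange or anything near it; the step of a number 9.9 percentage points lower from compound 2 to compound 3 (within the scatter) concerns another position and was itself within the scatter, so it gives no direction for the present change. Compound 4 is therefore expected to sit close to compound 1, with a number 6.3 percentage points lower from compound 1 to compound 4 (within the scatter) as the estimated step, carrying wide uncertainty. The estimate for compound 4 in this assay is 28%, with an expected range from 5% to 50%.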

Compound 4, a percentage reported as inhibition, at one concentration (the size of the read-out at that concentration, not a potency): 27.8%
The estimate for compound 4 lay 0.2 percentage points above the measured number, and the stated range covers the measured number.
By their numbers in this assay, from the lowest: compounds 3, 2, 4 and 1 (each within the scatter of the next, the first and the last beyond it).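

In this assay, the exchange on the aromatic carbon opposite the ring nitrogen gives a number 6.5 percentage points lower from compound 1 to compound 4 (within the scatter). For the compounds shown here, this is the first reading at this position, as the only earlier step concerned another place in the molecule. It shows that, in the setting of compound 1, this carbon can carry carboxy, with three heavy atoms in place of the single heavy atom of hydroxy, without a difference in the read-out that stands out from the scatter, so hydroxy is not shown to be required here at the one concentration tested. The data offer no independent measurement that would explain this result.

The compounds shown leave open how an amine, a methyl ester or a primary amide would read at this position, and thus whether the tolerance seen for carboxy extends to other groups. They also leave open whether the same exchange would give a similar result on the simpler substitution pattern of compound 3, or whether it depends on the fluorine and trifluoromethyl groups present in compound 1.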